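A few compounds are considered here, and "the series" means these few. Any claim that something is new, unique, unknown or untested is made for them only; others in the source may bear on it.

Measured compounds:
compound 1, `CCOc1nc(N)nc2[nH]cnc12`: > 1000000 nM in an assay on HT-29 cells for inhibition of Methylated-DNA--protein-cysteine methyltransferase (Homo sapiens) (a lower number here means a stronger inhibitor, a higher number a weaker inhibitor), a limit of the assay rather than a number.
compound 2, `CCCCOc1nc(N)nc2[nH]cnc12`: 493000 nM.

Compound 2 holds the only number shown in this assay; the other value recorded is a limit. The step from compound 1 to compound 2 reads an at least 2.0-fold lower number from compound 1 to compound 2 (0.30 log units; that floor lies within the scatter), and it rests on (the limit of > 1000000 nM in this assay, at which 1 of the 2 values shown sits), so only a floor for that step is known.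

Compound 3, `CCCCCCCOc1nc(N)nc2[nH]cnc12`, is not yet measured. It differs from compound 2 by propyl in place of hydrogen on a saturated chain carbon, four bonds along the chain from an oxygen on an aromatic ring. For the measured compounds named here, the one measured step, a lengthening of the same chain, gave only a floor that sits within the scatter, so no firm direction is established for further lengthening; the number is expected to move down modestly at best, if at all. Compound 3 is therefore expected to give about 250000 nM, within 80000 nM to 800000 nM, an expected step of a 2.0-fold lower number from compound 2 to compound 3 (0.29 log units; within the scatter).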

Compound 3, half-maximal inhibitory concentration: > 100000 nM
Compound 3 was reported as a limit (the forecaster's own chance of this, stated with the estimate: 15%); the middle value is on the limit's open side.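

For compound 3, > 100000 nM in this assay is a limit of the assay and not a number, so neither the step from compound 2 nor the step from compound 1 can be read. The compounds shown leave open whether the longer chain of compound 3 gives a lower or a higher number than compound 2.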